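The source may hold more compounds than are shown below. What is called first, only, known or untested is meant among the compounds shown, and "the series" means these compounds.

Measured so far:
- Compound 1, `NC(=O)c1c(NC(=O)c2ccccc2C(F)(F)F)sc2c1CCN(C(=S)Nc1ccccc1Cl)C2`: 17600 nM
- Compound 2, `NC(=O)c1c(NC(=O)c2ccccc2I)sc2c1CCN(C(=S)Nc1ccccc1Br)C2`: 18900 nM
- Compound 3, `NC(=O)c1c(NC(=O)c2ccccc2I)sc2c1CCN(C(=S)Nc1ccccc1C(F)(F)F)C2`: 19700 nM

All three values come from a functional assay on HL-60 cells (Homo sapiens) for antiproliferative activity, with a stated time of 24 h; on this read-out higher numbers stand for weaker inhibition and lower numbers for stronger inhibition. Compound 2 stands second highest of the three numbers, but its neighbours lie within the scatter on both sides: compound 3 is the nearest, compound 1 the furthest. Compound 4, `NC(=O)c1c(NC(=O)c2ccccc2C(F)(F)F)sc2c1CCN(C(=S)Nc1ccccc1Br)C2`, is not yet measured; it differs from compound 2 by trifluoromethyl in place of iodo on an aromatic carbon. Within the data shown here, the only measured step of one change is a 1.0-fold higher number from compound 2 to compound 3 (0.02 log units; within the scatter), which swaps a halogen for trifluoromethyl on the other ring and stays within the scatter. Compound 1, which already carries the trifluoromethyl that compound 4 will have, sits close to the rest. No step beyond the scatter is therefore expected, a 1.1-fold lower number from compound 2 to compound 4 (0.02 log units; within the scatter). Compound 4 is expected to give 18000 nM, between 9000 nM and 36000 nM.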

Compound 4, half-maximal inhibitory concentration: 25500 nM
Compound 4: middle estimate off by 1.4-fold (0.15 log units), on the low side; measured number inside the range.
By their numbers in this assay, from the lowest: compounds 1, 2, 3 and 4 (each within the scatter of the next).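

In this assay, the aromatic carbon that carries iodo also accepts trifluoromethyl, four heavy atoms in place of one, with a 1.3-fold higher number from compound 2 to compound 4 (0.13 log units; within the scatter). A second single change, bromo in place of chloro, gives a 1.4-fold higher number from compound 1 to compound 4 (0.16 log units; within the scatter), so neither change moves the number beyond the scatter. No outside evidence bears on this result. Going by these compounds, whether an amine or a carboxylic acid on this carbon would move the number beyond the scatter remains open. So does the effect of replacing the thiourea sulfur with oxygen.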